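Cytotoxicity of four benzamide analogues in mouse macrophages

A few compounds are considered here, and "the series" means these few. Any claim that something is new, unique, unknown or untested is made for them only; others in the source may bear on it.

Measured so far:
compound 1, `CC(C)(C)OC(=O)N(Cc1ccco1)C(=O)c1ccc(CN2Cc3ccccc3S2(=O)=O)cc1`, > 100000 nM
compound 2, `O=C(NCc1ccco1)c1ccc(CN2Cc3ccccc3S2(=O)=O)cc1`, > 100000 nM
compound 3, `CC(C)(C)OC(=O)N(Cc1ccco1)C(=O)c1ccc(Cn2sc3ccccc3c2=O)cc1`, > 100000 nM

Of the compounds shown here, three have been tested in an ADME assay on RAW264.7 cells (Mus musculus) for cytotoxicity, read by WST assay; a higher number here means that more compound is tolerated, a lower number that less compound is tolerated. Compound 1, `CC(C)(C)OC(=O)N(Cc1ccco1)C(=O)c1ccc(CN2Cc3ccccc3S2(=O)=O)cc1`, gives a value of > 100000 nM, which is a limit of the assay rather than a number. Compound 2, `O=C(NCc1ccco1)c1ccc(CN2Cc3ccccc3S2(=O)=O)cc1`, also gives a limit, > 100000 nM. Compound 3, `CC(C)(C)OC(=O)N(Cc1ccco1)C(=O)c1ccc(Cn2sc3ccccc3c2=O)cc1`, gives a limit as well, > 100000 nM. The change from compound 1 to compound 2 is hydrogen in place of tert-butoxycarbonyl on an amide-type nitrogen, and its step in this assay is a step that the two limits leave unreadable from compound 1 to compound 2. The change from compound 1 to compound 3 is a group of 10 heavy atoms (7 carbon, 1 nitrogen, 1 oxygen, 1 sulfur; one five-membered aromatic ring with 2 hetero atoms, one six-membered aromatic ring of carbon only) in place of a group of 11 heavy atoms (7 carbon, 1 nitrogen, 2 oxygen, 1 sulfur; one five-membered non-aromatic ring with 2 hetero atoms, one six-membered aromatic ring of carbon only), on a saturated chain carbon bound to an aromatic carbon, with a step that the two limits leave unreadable from compound 1 to compound 3. All three values sit at the limit of > 100000 nM in this assay, at which 3 of the 3 values shown sit, so none of the steps can be sized.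

Compound 4, `O=C(NCc1ccco1)c1ccc(Cn2sc3ccccc3c2=O)cc1`, has not been measured. It differs from compound 3 by hydrogen in place of tert-butoxycarbonyl on an amide-type nitrogen, the same change as that from compound 1 to compound 2. Because compound 1 and compound 2 both sit at the limit of > 100000 nM in this assay, at which 3 of the 3 values shown sit, that change did not bring either compound into the readable range. On that basis compound 4 is expected to sit at the limit as well, with an estimated step that the limit leaves unreadable from compound 3 to compound 4. The estimate for compound 4 in this assay is 150000 nM, between 60000 nM and 400000 nM.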

Compound 4, concentration lethal to 50% of the cells: > 100000 nM
Compound 4: only a limit was reported (the forecaster's own chance of this, stated with the estimate: 85%); the middle value lies beyond the limit too.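

In this assay, compound 4 also gives a limit, so the step from compound 3 to compound 4 cannot be read, and no step among the four compounds can be sized: the limit of > 100000 nM in this assay, at which 4 of the 4 values shown sit.

The compounds shown leave open where the tolerated concentration of each one actually lies, and whether hydrogen in place of tert-butoxycarbonyl changes it at all.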